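The source may hold more compounds than are shown below. What is called first, only, known or untested is meant among the compounds shown, and "the series" means these compounds.

Series notes. Compound 1 `N#CC1=C(N)Oc2c(N)cc3nc4ccccc4nc3c2C12C(=O)N(Cc1cnnn1-c1cccc(Br)c1)c1ccccc12` carries 3-bromophenyl on the aromatic nitrogen. In an ADME assay on HUVEC cells (Homo sapiens) for antiproliferative activity, read by MTT assay, with a stated time of 48 h (a lower number here means a stronger inhibitor, a higher number a weaker inhibitor), compound 1 gives only a limit, > 50000 nM. Compound 2 `COc1ccccc1-n1nncc1CN1C(=O)C2(C(C#N)=C(N)Oc3c(N)cc4nc5ccccc5nc4c32)c2ccccc21` carries 2-methoxyphenyl in place of 3-bromophenyl on an aromatic nitrogen. In this assay compound 2 likewise returns a limit, > 50000 nM. The step that the two limits leave unreadable from compound 1 to compound 2 cannot be given a size because both ends rest at the limit of > 50000 nM in this assay, at which 2 of the 2 values shown sit. Compound 2 thus stands, on the numbers shown, at that limit and nothing finer.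

Compound 3 `CCOc1ccc(-n2nncc2CN2C(=O)C3(C(C#N)=C(N)Oc4c(N)cc5nc6ccccc6nc5c43)c3ccccc32)cc1` differs from compound 2 by 4-ethoxyphenyl in place of 2-methoxyphenyl on an aromatic nitrogen. For the measured compounds named here, the one measured step that bears on this aromatic nitrogen, a step that the two limits leave unreadable from compound 1 to compound 2, yields no readable size, so neither direction nor magnitude of change can be drawn from it. The expectation for compound 3 in this assay is therefore a further limit rather than a number, estimated at 60000 nM with a range from 20000 nM to 200000 nM. As a step, the estimate means a step that the limit leaves unreadable from compound 2 to compound 3 is expected.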

Compound 3, half-maximal inhibitory concentration: > 50000 nM
Compound 3: only a limit was reported; the forecaster's own chance of this, stated with the estimate: 75%; the middle value does not contradict the limit.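

For the compounds shown here, no step among compound 1, compound 2 and compound 3 can be read in this assay, as all three rest at one limit: the limit of > 50000 nM in this assay, at which 3 of the 3 values shown sit. The compounds shown leave open whether the three groups on the aromatic nitrogen differ at all in this assay, and by how much.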